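This account rests on a few compounds, and the source may have more. Where it says the series, first, only, none or still open, it means among the compounds named here.

Measured so far in a functional assay on ileum for inhibition of histamine H1 receptor (Cavia porcellus); a higher number here means a weaker inhibitor, a lower number a stronger inhibitor:
compound 1 `CCCCOCCn1c(N2CCCN(C)CC2)nc2ccccc21` — 10 nM
compound 2 `CCCCCCCn1c(N2CCN(C)CC2)nc2ccccc21` — 150 nM
compound 3 `CCCCN1CCN(c2nc3ccccc3n2CCOCC)CC1` — 15 nM

Compound 2 stands highest of the three numbers in this assay. The gap to compound 3 lies beyond the usual scatter, and the gap to compound 1 is wider still, also beyond the scatter. Among the compounds with values here, none of the three pairs differs in a single place, so no isolated step is available.

Compound 4 `COCCCn1c(N2CCN(C)CC2)nc2ccccc21` is compound 2 with methoxy in place of butyl on a saturated chain carbon, three bonds along the chain from an aromatic nitrogen; read one bond further out, the chain on the aromatic nitrogen goes from heptyl to 3-methoxypropyl. The chains of compound 1 and of compound 3 likewise contain an oxygen atom, and both sit well below compound 2 in this assay, but each of them also differs from compound 2 elsewhere, so the weight carried by the chain alone is not known. A step toward a lower number, probably beyond the scatter, is expected. Compound 4 is estimated at 35 nM, range 8 nM to 150 nM, which means an expected step of a 4.3-fold lower number from compound 2 to compound 4 (0.63 log units; beyond the scatter).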

Compound 4, half-maximal inhibitory concentration: 860 nM
Beside the measured number, compound 4's estimate is 25-fold (1.39 log units) below it; the whole stated range lies below it.
By their numbers in this assay, from the lowest: compounds 1 and 3 (each within the scatter of the next); then compound 2; then compound 4.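

In this assay, replacing butyl with methoxy on a saturated chain carbon, three bonds along the chain from an aromatic nitrogen, gives a 5.7-fold higher number from compound 2 to compound 4 (0.76 log units; beyond the scatter). At this position, then, an oxygen in the chain does not by itself bring the number down, and the low values of compound 1 and compound 3 cannot be credited to the oxygen in their chains. The change also swaps butyl for the smaller methoxy, so this single step joins a shorter chain and an added oxygen, and no measurement at hand accounts for the rise.

Still open, going by these compounds, is which of the two parts of the change carries the step; a pentyl chain on the core of compound 2 would separate them. Also open, on these data alone, is how this position responds to a chain ending in an amine or a carboxylic acid.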